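The compounds below may be only part of what the source reports. "The series", "measured", "known", "first", "only" and "open" are said of these compounds alone.

Among the measured compounds shown here, in a functional assay on HeLa cells (Homo sapiens) for inhibition, read by MTT assay, with a stated time of 48 h (a higher number here means a weaker inhibitor, a lower number a stronger inhibitor), compound 2 `COc1cccc(C(c2c[nH]c3ccc(Br)cc23)c2c[nH]c3ccc(Br)cc23)c1OC` gives 64500 nM, the highest of the three numbers so far, which makes it the weakest inhibitor of the set. Compound 1 `c1ccc(C(c2c[nH]c3ccccc23)c2c[nH]c3ccccc23)cc1` gives 21800 nM, and compound 3 `COc1ccc(C(c2c[nH]c3ccc(Br)cc23)c2c[nH]c3ccc(Br)cc23)cc1OC` gives 6100 nM. Compound 4 `Brc1ccc2[nH]cc(C(c3c[nH]c4ccc(Br)cc34)C3CCCCC3)c2c1` differs from compound 2 in one place, on a saturated chain carbon bound to two aromatic carbons, where cyclohexyl stands in place of 2,3-dimethoxyphenyl: cyclohexyl in place of 2,3-dimethoxyphenyl on a saturated chain carbon bound to two aromatic carbons. For the measured compounds named here, only one measured step bears on this change. It is an 11-fold lower number from compound 2 to compound 3 (1.02 log units; beyond the scatter), a large step made by changing the group at that same place, so the number in this assay can move strongly there. Going by the values given here, no measured compound carries cyclohexyl, so that step shows sensitivity and not a direct answer. Compound 2 already sits at the top of the measured numbers, so a fall seems likelier than a rise, though probably a smaller one than that step. The expected change is a 3.6-fold lower number from compound 2 to compound 4 (0.55 log units; beyond the scatter). For compound 4 the estimated value is 18000 nM, with an expected range of 5000 nM to 60000 nM.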

Compound 4, half-maximal inhibitory concentration: 3200 nM
Estimate against measurement, compound 4: 5.6-fold (0.75 log units) above, outside the stated range (below it).
By their numbers in this assay, from the lowest: compounds 4 and 3 (each within the scatter of the next); then compound 1; then compound 2.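

Replacing 2,3-dimethoxyphenyl with cyclohexyl gives a 20-fold lower number from compound 2 to compound 4 (1.30 log units; beyond the scatter) in this assay, so a low number at this place on a saturated chain carbon bound to two aromatic carbons does not require an aromatic ring or methoxy groups. Cyclohexyl in place of 3,4-dimethoxyphenyl gives a 1.9-fold lower number from compound 3 to compound 4 (0.28 log units; within the scatter) and leaves those two groups indistinguishable here, which sets the 2,3-dimethoxyphenyl group of compound 2 apart among these three groups. Nothing available explains this difference between the groups.

As far as these compounds go, it remains open whether a cyclopentyl ring, an open butyl chain or a cyclohexyl ring carrying an amine would keep the number this low at the same place. From the compounds shown here alone, it is also open whether cyclohexyl would give a similar number on the core of compound 1, which has no bromine.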